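The compounds below may be only part of what the source reports. "The series", "measured", "known", "first", "only" and "open" are said of these compounds alone.

Three compounds sharing one core have been measured in a functional assay on HCC827 cells (Homo sapiens) for antiproliferative activity, read by sulforhodamine B assay, with a stated time of 72 h; on this read-out lower numbers stand for stronger inhibition and higher numbers for weaker inhibition:

Compound 1, `CN(CCNCc1cn(-c2ccccc2)nn1)CCNc1ccnc2cc(Cl)ccc12`, gives 26000 nM
Compound 2, `CN(CCNCc1cn(-c2ccc(F)cc2)nn1)CCNc1ccnc2cc(Cl)ccc12`, gives 19000 nM
Compound 3, `CN(CCNCc1cn(-c2ccc(Br)cc2)nn1)CCNc1ccnc2cc(Cl)ccc12`, gives 11000 nM

Compound 3 has the lowest number of the three. The step of a 1.7-fold lower number from compound 2 to compound 3 (0.24 log units; within the scatter) is within the scatter, while the step of a 2.4-fold lower number from compound 1 to compound 3 (0.37 log units; beyond the scatter) is a modest one that lies beyond it. The step of a 1.4-fold lower number from compound 1 to compound 2 (0.14 log units; within the scatter) also stays within the scatter, so the three numbers sit close together.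

Compound 4, `CN(CCNCc1cn(C(C)(C)C)nn1)CCNc1ccnc2cc(Cl)ccc12`, is the next compound. Its change from compound 3 is tert-butyl in place of 4-bromophenyl on an aromatic nitrogen. Among the measured compounds shown here, none of the measured steps covers this kind of change: all three only swap substituents on the phenyl ring while keeping the ring itself, and their effects were small. On these data alone, removing the ring altogether is untested here, so the direction can only be guessed from the fact that the unsubstituted phenyl of compound 1 gave the highest number among the three. A shift back toward or beyond that number, in the direction of weaker inhibition, is the expectation, with wide uncertainty.

Compound 4 is therefore expected to give 30000 nM, with a likely range from 12000 nM to 75000 nM, which corresponds to an estimated step of a 2.7-fold higher number from compound 3 to compound 4 (0.44 log units; beyond the scatter).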

Compound 4, half-maximal inhibitory concentration: 56000 nM
For compound 4 the middle estimate is 1.9-fold (0.27 log units) below the measured one; low and high end bracket the measured number.
By their numbers in this assay, from the lowest: compounds 3, 2 and 1 (each within the scatter of the next, the first and the last beyond it); then compound 4.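

In this assay, the group on the aromatic nitrogen of the five-membered ring clearly matters: replacing the aromatic ring there with tert-butyl gives a 5.1-fold higher number from compound 3 to compound 4 (0.71 log units; beyond the scatter), a 2.9-fold higher number from compound 2 to compound 4 (0.47 log units; beyond the scatter) and a 2.2-fold higher number from compound 1 to compound 4 (0.33 log units; beyond the scatter), which makes compound 4 the weakest of the four. All three steps lie beyond the scatter, whereas among the earlier changes on the phenyl ring only bromo in place of hydrogen did, so removing the ring shows an effect that halogen swaps mostly did not. No measurement at hand explains this shift.

Tert-butyl differs from the phenyl groups both in having no ring and in its heavy atoms, so the compounds shown cannot tell which of these differences counts. A cyclohexyl group, which keeps a ring without being aromatic, or a benzyl group or a straight butyl chain on the same nitrogen could help separate them, while an amine or a carboxylic acid on the phenyl ring would test kinds of substituent beyond the halogens seen so far.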